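Notes on compound 4 and the step from compound 1

A few compounds are considered here, and "the series" means these few. Any claim that something is new, unique, unknown or untested is made for them only; others in the source may bear on it.

Measured so far:
Compound 1 `N/C(=N\O)c1c(Cl)n(C2O[C@H](CO)[C@@H](O)[C@H]2O)c2cc(Cl)c(Cl)cc12` — > 100000 nM
Compound 2 `CC(=O)N/N=C/c1c(Cl)n(C2O[C@H](CO)[C@@H](O)[C@H]2O)c2cc(Cl)c(Cl)cc12` — 9000 nM
Compound 3 `OC[C@H]1OC(n2c(Cl)c(/C=N/O)c3cc(Cl)c(Cl)cc32)[C@H](O)[C@@H]1O` — 25000 nM

All values come from a functional assay on KB cells (Homo sapiens) for cytotoxicity, read by spectrophotometry and crystal violet staining; on this read-out higher numbers stand for weaker inhibition and lower numbers for stronger inhibition. For compound 1 the value > 100000 nM is a limit of the assay and not a number, so compound 1 stands only at that limit (the limit of > 100000 nM in this assay, at which 1 of the 3 values shown sits). Both measured steps away from compound 1 lower the number: an at least 11-fold lower number from compound 1 to compound 2 (1.04 log units; beyond the scatter) and an at least 4.0-fold lower number from compound 1 to compound 3 (0.60 log units; beyond the scatter). Between the two measured replacements the difference is a 2.8-fold higher number from compound 2 to compound 3 (0.44 log units; beyond the scatter).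

Compound 4 `COC(=N)c1c(Cl)n(C2O[C@H](CO)[C@@H](O)[C@H]2O)c2cc(Cl)c(Cl)cc12` differs from compound 1 in one place: a group of 4 heavy atoms (2 carbon, 1 nitrogen, 1 oxygen; no ring) in place of a group of 4 heavy atoms (1 carbon, 2 nitrogen, 1 oxygen; no ring), on an aromatic carbon

The steps from compound 1 to compound 2 and from compound 1 to compound 3 bear on this change, as each also replaces the group of 4 heavy atoms on that aromatic carbon, and each gave an at least modest lower number. A lower number is therefore expected for compound 4 as well, though its size is uncertain while compound 1 sits at a limit. Compound 4 is expected to give 40000 nM, within 10000 nM to 150000 nM. For compound 4 this means an estimated step of an at least 2.5-fold lower number from compound 1 to compound 4 (0.39 log units; beyond the scatter).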

Compound 4, half-maximal inhibitory concentration: 50000 nM
The estimate for compound 4 lay 1.3-fold (0.10 log units) below the measured number, within the range that was stated.
By their numbers in this assay, from the lowest: compound 2; then compounds 3 and 4 (each within the scatter of the next). At a limit, above all of these: compound 1.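

Compound 1 remains a limit and not a number in this assay: the limit of > 100000 nM in this assay, at which 1 of the 4 values shown sits.

Measured against that limit, the new group gives an at least 2.0-fold lower number from compound 1 to compound 4 (0.30 log units; that floor lies within the scatter), so a change on this aromatic carbon does not always clear the scatter at its floor, unlike the two earlier replacements of the same group. With a 2.0-fold higher number from compound 3 to compound 4 (0.30 log units; within the scatter), the new group and the hydroxy-bearing group are not separated, whereas with a 5.6-fold higher number from compound 2 to compound 4 (0.74 log units; beyond the scatter), the acetamido-bearing group stands clear of the new group as it does of the hydroxy-bearing one.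

The compounds shown leave open how a carboxylic acid, an amine or a longer chain on this aromatic carbon would read. They also leave open how far the group in compound 1 truly lies from the others, since only its limit is available.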